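A few compounds are considered here, and "the series" means these few. Any claim that something is new, unique, unknown or untested is made for them only; others in the source may bear on it.

Compound 1 `Cn1c(Cc2nn(C)c(=O)c3ccccc23)nnc1SCCCCCCCC(=O)Nc1ccc(Cl)cc1Cl`: 2200 nM
Compound 2 `Cn1nc(Cc2nnc(SCCCCCCCC(=O)Nc3ccc(Cl)cc3Cl)n2CCCO[Si](C)(C)C(C)(C)C)c2ccccc2c1=O`: > 30000 nM
Compound 3 `Cn1nc(Cc2nnc(SCCCCCCCC(=O)Nc3ccc(Cl)cc3Cl)n2CCC(=O)O)c2ccccc2c1=O`: 23500 nM

In an assay on 32D cells for inhibition of interleukin-15 (Mus musculus), read by resazurin assay, with stated times of 30 min and 2.5 days, in the presence of a further agent that is not named here (a lower number here means a stronger inhibitor, a higher number a weaker inhibitor), compound 1 gives 2200 nM, the lowest of the numbers shown for the set. The value of compound 2 is a limit of the assay and not a number, namely (the limit of > 30000 nM in this assay, at which 1 of the 3 values shown sits). Compound 4 `CN(C)CCCn1nc(Cc2nnc(SCCCCCCCC(=O)Nc3ccc(Cl)cc3Cl)n2C)c2ccccc2c1=O` differs from compound 1 by 2-(dimethylamino)ethyl in place of hydrogen on a saturated chain carbon bound to an aromatic nitrogen. Two measured steps alter the same place on the core of compound 1: an at least 13-fold higher number from compound 1 to compound 2 (1.13 log units; beyond the scatter) and an 11-fold higher number from compound 1 to compound 3 (1.03 log units; beyond the scatter). Both additions at this position gave large increases, so a similar increase is expected for compound 4, estimated as a 6.8-fold higher number from compound 1 to compound 4 (0.83 log units; beyond the scatter). Compound 4 is therefore expected to give about 15000 nM in this assay, with a range from 5000 nM to 40000 nM.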

Compound 4, half-maximal inhibitory concentration: 2300 nM
For compound 4 the middle estimate is 6.5-fold (0.81 log units) above the measured one; the whole stated range lies above it.
By their numbers in this assay, from the lowest: compounds 1 and 4 (each within the scatter of the next); then compound 3. At a limit, above all of these: compound 2.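

In this assay, the saturated chain carbon bound to an aromatic nitrogen takes 2-(dimethylamino)ethyl in place of hydrogen without a step beyond the scatter: a 1.0-fold higher number from compound 1 to compound 4 (0.02 log units; within the scatter). Additions at this place therefore do not all raise the number, unlike carboxymethyl, which gave an 11-fold higher number from compound 1 to compound 3 (1.03 log units; beyond the scatter). Nothing shown here gives a cause for this contrast.

From the compounds shown here alone, what stays open is whether a longer chain ending in the same amine, or a chain ending in a hydroxyl or a primary amide, would also stay within the scatter of compound 1.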